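A few compounds are considered here, and "the series" means these few. Any claim that something is new, unique, unknown or untested is made for them only; others in the source may bear on it.

Working notes on the series, growth inhibition track.

Of the compounds shown here, two of the shared core have numbers so far. Compound 1 `Nc1cc(N)c2nc(-c3ccccc3)c(NCc3ccc(Cl)c(Cl)c3)nc2c1` gives 55000 nM in a functional assay on SF-268 cells (Homo sapiens) for inhibition, read by sulforhodamine B assay, with a stated time of 48 h; a lower number here means a stronger inhibitor of growth, a higher number a weaker inhibitor of growth. Compound 2 `COc1ccc(CNc2nc3cc(N)cc(N)c3nc2-c2ccccc2)cc1OC` gives 60300 nM in this assay; its number and that of compound 1 lie within the scatter of each other, so nothing separates them. For the measured compounds named here, the one step available, a 1.1-fold higher number from compound 1 to compound 2 (0.04 log units; within the scatter), shows that exchanging the aryl on the saturated chain carbon bound to the ring nitrogen left the read-out unmoved.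

The next compound, compound 3 `COc1cc(CNc2nc3cc(N)cc(N)c3nc2-c2ccccc2)cc(OC)c1OC`, differs from compound 2 by methoxy in place of hydrogen on an aromatic carbon. Going by the values given here, no measured pair adds a methoxy to this ring, so the only guide is the step from compound 1 to compound 2, which was within the scatter after a larger exchange on the same ring. On that basis no step beyond the scatter is expected in this assay for compound 3, in either direction; the expected step is a 1.0-fold lower number from compound 2 to compound 3 (0.00 log units; within the scatter). Compound 3 is accordingly estimated at 60000 nM, with a range from 30000 nM to 120000 nM.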

Compound 3, concentration for total growth inhibition: 14100 nM
For compound 3 the middle estimate is 4.3-fold (0.63 log units) above the measured one; measured number below the stated range.
By their numbers in this assay, from the lowest: compound 3; then compounds 1 and 2 (each within the scatter of the next).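

In this assay, for the compounds shown here, methoxy in place of hydrogen gives a 4.3-fold lower number from compound 2 to compound 3 (0.63 log units; beyond the scatter), the first step to lie beyond the scatter. The aryl on the saturated chain carbon is therefore not indifferent to substitution: the exchange of chlorines for methoxy groups in a 1.1-fold higher number from compound 1 to compound 2 (0.04 log units; within the scatter) left the number unmoved, whereas one further methoxy, on the aromatic carbon ortho to a methoxy group and meta to a large group, does move it, toward stronger growth inhibition. No measurement in hand bears on why this added group shifts the read-out.

From the compounds shown here alone, the step rests on a single pair, so it remains open whether the shift belongs to methoxy itself or would also follow from another group on the same aromatic carbon, such as a hydroxyl, a fluorine, an ethoxy or an amine. Also open, going by these compounds, is whether the same methoxy would give a step of similar size with other groups on the ring, for instance with the chlorines of compound 1 in place of the two methoxy groups of compound 2.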